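The source may report more compounds than this note shows. Statements on the series, on what has been measured and on what is new or still open speak of the compounds shown alone.

Measured compounds:
- compound 1 `Oc1ccc(/C=N\NC(=S)NC2CCCCC2)c(O)c1`: 56600 nM
- compound 2 `S=C(N/N=C\c1ccc(Cl)cc1)NC1CCCCC1`: 38300 nM
- compound 3 `CN(C)c1ccc(/C=N\NC(=S)NC2CCCCC2)cc1`: 125000 nM

All three share one core and differ only in the groups on the aromatic ring. In a functional assay on MDA-MB-231 cells (Homo sapiens) for inhibition, read by WST assay, with a stated time of 48 h (on this read-out higher numbers stand for weaker inhibition and lower numbers for stronger inhibition), compound 3 gives the highest of the three numbers: compound 1 gives a lower one, and compound 2 the lowest, both gaps lying beyond the scatter. Among the compounds with values here, the single one-place step among them, a 3.3-fold higher number from compound 2 to compound 3 (0.51 log units; beyond the scatter), involves the dimethylamino group that compound 3 carries.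

Compound 4 `Oc1ccc(/C=N\NC(=S)NC2CCCCC2)cc1` is not yet measured. It differs from compound 3 by hydroxy in place of dimethylamino on an aromatic carbon. Within the data shown here, no measured pair swaps these two groups directly. What bears on it is a 3.3-fold higher number from compound 2 to compound 3 (0.51 log units; beyond the scatter), which shows that putting dimethylamino on the ring went with a higher number, and compound 1, which carries hydroxy groups and gives a lower number than compound 3. Removing dimethylamino in favour of hydroxy is therefore expected to lower the number in this assay, by a 2.1-fold lower number from compound 3 to compound 4 (0.32 log units; beyond the scatter). Compound 4 is estimated at 60000 nM, within a range from 25000 nM to 150000 nM.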

Compound 4, half-maximal inhibitory concentration: 115000 nM
The estimate for compound 4 lay 1.9-fold (0.28 log units) below the measured number; the measured number falls inside the stated range.
By their numbers in this assay, from the lowest: compounds 2 and 1 (each within the scatter of the next); then compounds 4 and 3 (each within the scatter of the next).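

In this assay, hydroxy in place of dimethylamino on this aromatic carbon, para to a large group, gives a 1.1-fold lower number from compound 3 to compound 4 (0.04 log units; within the scatter) and so does not separate these two groups. Chloro at the same place does stand apart, since hydroxy in its place gives a 3.0-fold higher number from compound 2 to compound 4 (0.48 log units; beyond the scatter) and the lower number of compound 2 therefore goes with chloro rather than with the mere absence of dimethylamino. Hydrogen in place of one hydroxy gives a 2.0-fold higher number from compound 1 to compound 4 (0.31 log units; beyond the scatter) so a single hydroxy on the ring does not match the lower number of compound 1, which carries an additional hydroxy.

No measurement shown here explains these differences. From the compounds shown here alone, whether a methoxy group, a fluoro group or a primary amine at this place would group with chloro or with hydroxy and dimethylamino remains open.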